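Swapping fluoro for cyano on compound 3

The source may hold more compounds than are shown below. What is called first, only, known or untested is meant among the compounds shown, and "the series" means these compounds.

Of the compounds shown here, three sharing one core have been measured in a physicochemical assay for solubility, at pH 6.8; on this read-out lower numbers stand for lower solubility and higher numbers for higher solubility. With ethyl on a carbonyl carbon, compound 1 `CCC(=O)N[C@@H](C)c1ccc(NC(=O)[C@H]2C[C@@H]2c2cccnc2)cc1` gives 54000 nM. With 1-methylpyrrolidin-2-yl at that carbon, compound 2 `C[C@H](NC(=O)[C@@H]1CCCN1C)c1ccc(NC(=O)[C@H]2C[C@@H]2c2cccnc2)cc1` gives 730000 nM. With 4-fluorophenyl there, compound 3 `C[C@H](NC(=O)c1ccc(F)cc1)c1ccc(NC(=O)[C@H]2C[C@@H]2c2cccnc2)cc1` gives 6000 nM, the lowest number of the three.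

The next compound, compound 4 `C[C@H](NC(=O)c1ccc(C#N)cc1)c1ccc(NC(=O)[C@H]2C[C@@H]2c2cccnc2)cc1`, differs from compound 3 in one place: cyano in place of fluoro on an aromatic carbon, para to a large group (cyano in place of fluoro on an aromatic carbon).

Three measured steps offer some guidance, though none shows this swap directly. Replacing ethyl with 4-fluorophenyl gave a 9.0-fold lower number from compound 1 to compound 3 (0.95 log units; beyond the scatter), a modest step. Replacing 1-methylpyrrolidin-2-yl with 4-fluorophenyl gave a 120-fold lower number from compound 2 to compound 3 (2.09 log units; beyond the scatter), and replacing ethyl with 1-methylpyrrolidin-2-yl gave a 14-fold higher number from compound 1 to compound 2 (1.13 log units; beyond the scatter), both large. Each of those steps exchanged the whole group on the carbonyl carbon, whereas compound 4 keeps the six-membered aromatic ring of compound 3 at 6000 nM. A much smaller step is therefore expected in this assay, with no clear direction and probably nothing beyond the scatter. The expected step is a 1.2-fold lower number from compound 3 to compound 4 (0.08 log units; within the scatter). The estimate for compound 4 is 5000 nM, with an expected range of 1800 nM to 14000 nM.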

Compound 4, solubility: 175000 nM
For compound 4 the middle estimate is 35-fold (1.54 log units) below the measured one; measured number above the stated range.
By their numbers in this assay, from the lowest: compound 3; then compound 1; then compound 4; then compound 2.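

In this assay, within the data shown here, the group on the aromatic carbon para to a large group turns out to matter far more than the earlier compounds could show: replacing fluoro with cyano, while the rest of the molecule stays the same, gives a 29-fold higher number from compound 3 to compound 4 (1.46 log units; beyond the scatter) as a large step, in the same range as the earlier exchanges of the whole group on the carbonyl carbon. The presence of a six-membered aromatic ring therefore does not by itself set the number, since 4-fluorophenyl sits below ethyl whereas 4-cyanophenyl gives a 3.2-fold higher number from compound 1 to compound 4 (0.51 log units; beyond the scatter) as a modest step in the opposite direction, and 1-methylpyrrolidin-2-yl remains the highest of the groups compared, with a 4.2-fold lower number from compound 2 to compound 4 (0.62 log units; beyond the scatter) as another modest step. Nothing measured here accounts for the size of the change from fluoro to cyano.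

Going by these compounds, it remains open whether this large step is particular to cyano, as a methoxy group, an amine or a carboxylic acid on the same aromatic carbon could show. On these data alone, it is also open whether cyano would give a step of similar size on a different carbon of that ring or on another core.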